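Lengthening the propoxy chain of compound 1 with an amine

A few compounds are considered here, and "the series" means these few. Any claim that something is new, unique, unknown or untested is made for them only; others in the source may bear on it.

Within the data shown here, compound 1 `CCCOc1c(-c2cc(OC)c(OC)c(OC)c2)oc2ccccc2c1=O` is the only compound here with a plain number in a functional assay on DU-145 cells (Homo sapiens) for antiproliferative activity, read by WST assay, with a stated time of 3 days; a higher number here means a weaker inhibitor, a lower number a stronger inhibitor: compound 1 gives 2800 nM. Compound 2 `CCCCOc1c(-c2cc(OC)c(OC)c(OC)c2)oc2ccccc2c1=O` reaches only a limit of this assay, with > 50000 nM. Compound 3 `CCCCCCOc1c(-c2cc(OC)c(OC)c(OC)c2)oc2ccccc2c1=O` likewise stops at a limit, with > 50000 nM. Both steps away from compound 1 are therefore large: an at least 17-fold higher number from compound 1 to compound 2 (1.25 log units; beyond the scatter), and an at least 17-fold higher number from compound 1 to compound 3 (1.25 log units; beyond the scatter). Between the two longer chains the step cannot be read: a step that the two limits leave unreadable from compound 2 to compound 3. What the two weaker values share is the limit of > 50000 nM in this assay, at which 2 of the 3 values shown sit.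

Compound 4 `CCN(CC)CCCCOc1c(-c2cc(OC)c(OC)c(OC)c2)oc2ccccc2c1=O` has not yet been measured in this assay. It differs from compound 1 in a single place: (diethylamino)methyl in place of hydrogen on a saturated chain carbon, three bonds along the chain from an oxygen on an aromatic ring. The new group enters at the same chain carbon where compound 2 gained its methyl, so the steps from compound 1 to compound 2 and from compound 1 to compound 3 bear on it most, and both were large and ran to the limit. The expectation for compound 4 in this assay is accordingly a large weakening, an 11-fold higher number from compound 1 to compound 4 (1.03 log units; beyond the scatter). The value estimated for compound 4 is 30000 nM, within a range from 6000 nM to 60000 nM, with a real chance that only a limit is reported.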

Compound 4, half-maximal inhibitory concentration: 13300 nM
Estimate against measurement, compound 4: 2.3-fold (0.35 log units) above; the measured number falls inside the stated range.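

Lengthening the chain at this carbon does not by itself end the activity in this assay: the 4-(diethylamino)butyl chain of compound 4 still gives a plain number, and the loss relative to the propyl chain is modest, a 4.8-fold higher number from compound 1 to compound 4 (0.68 log units; beyond the scatter). Diethylamino in place of a hydrogen at the chain end gives an at least 3.7-fold lower number from compound 2 to compound 4 (0.57 log units; beyond the scatter), and diethylamino in place of an ethyl gives an at least 3.7-fold lower number from compound 3 to compound 4 (0.57 log units; beyond the scatter), so what sits at the end of the chain matters here, not the added length alone. These two steps give only a minimum size, because the plain longer chains reach only a limit of the assay: the limit of > 50000 nM in this assay, at which 2 of the 4 values shown sit.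

The compounds shown leave open whether the diethylamino group is needed as such, or whether a chain ending in a dimethylamino group, a morpholine or a hydroxyl would serve as well. They also leave open how chain length acts once an amine is present, and a 3-(diethylamino)propyl or 6-(diethylamino)hexyl chain on the shared core would show whether the activity of compound 1 can be matched or passed.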